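Aryl replacement and cytotoxicity within the shared core series

A few compounds are considered here, and "the series" means these few. Any claim that something is new, unique, unknown or untested is made for them only; others in the source may bear on it.

Compound 1 `COc1ccc(-c2csc(Nc3cc4[nH]c(=O)cnc4cc3N(C)C3CCCCC3)n2)cc1` gives 15000 nM in an ADME assay on Huh-7 cells (Homo sapiens) for cytotoxicity; on this read-out higher numbers stand for weaker inhibition and lower numbers for stronger inhibition. Compound 2 `CN(c1cc2ncc(=O)[nH]c2cc1Nc1nc(-c2cccc3ccccc23)cs1)C1CCCCC1` gives 57400 nM in this assay; the change from compound 1 brought a 3.8-fold higher number from compound 1 to compound 2 (0.58 log units; beyond the scatter). Going by the values given here, compound 2 therefore holds the highest of the two numbers so far, with compound 1 as its only neighbour. Compound 3 `CN(c1cc2ncc(=O)[nH]c2cc1Nc1nc(-c2cccnc2)cs1)C1CCCCC1` differs from compound 2 by pyridin-3-yl in place of naphthalen-1-yl on an aromatic carbon. Among the compounds with values here, the only measured step at this place is a 3.8-fold higher number from compound 1 to compound 2 (0.58 log units; beyond the scatter), in which 4-methoxyphenyl became naphthalen-1-yl and the number rose modestly; the move to pyridin-3-yl has no direct counterpart among the measured pairs. A step back toward the compound 1 number, or none beyond the scatter, is the expectation, with wide uncertainty. The estimate for compound 3 in this assay is 28000 nM, within a range of 9000 nM to 90000 nM. This estimate is expected to correspond to a 2.1-fold lower number from compound 2 to compound 3 (0.31 log units; beyond the scatter).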

Compound 3, half-maximal inhibitory concentration: 11500 nM
For compound 3 the middle estimate is 2.4-fold (0.39 log units) above the measured one, and the stated range covers the measured number.
By their numbers in this assay, from the lowest: compounds 3 and 1 (each within the scatter of the next); then compound 2.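

On the carbon of the five-membered aromatic ring with 1 nitrogen and 1 sulfur, the rise seen with naphthalen-1-yl reverses when pyridin-3-yl enters, with a 5.0-fold lower number from compound 2 to compound 3 (0.70 log units; beyond the scatter) in this assay. This step is larger than the earlier rise, and it shows that the number at this place can move in both directions. Pyridin-3-yl and 4-methoxyphenyl cannot be told apart here, with a 1.3-fold lower number from compound 1 to compound 3 (0.12 log units; within the scatter), so among these three compounds, only naphthalen-1-yl, the one group with 2 six-membered aromatic rings, stands apart from the others.

Unsubstituted phenyl, cyclohexyl, and a phenyl ring bearing an amine or a carboxylic acid would help separate ring count from the ring nitrogen and the methoxy group, which these compounds leave unresolved. No supporting data on hand explain either step.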